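Swapping 2,5-dimethoxyphenyl for 3-hydroxyphenyl on a shared core

This account rests on a few compounds, and the source may have more. Where it says the series, first, only, none or still open, it means among the compounds named here.

- Compound 1 (`COc1c(N2CCN(C)CC2)c(F)cc2c(=O)c(C(=O)N/N=C\c3c(Cl)cccc3Cl)cn(C3CC3)c12`) gives 4.9 ug/mL in a functional assay on PC-3 cells (Homo sapiens) for inhibition, read by MTT assay; a higher number here means a weaker inhibitor, a lower number a stronger inhibitor
- Compound 2 (`COc1ccc(OC)c(/C=N\NC(=O)c2cn(C3CC3)c3c(OC)c(N4CCN(C)CC4)c(F)cc3c2=O)c1`) gives 3 ug/mL in this assay

Within the data shown here, only two numbers exist so far, and compound 2 sits within the usual scatter of compound 1, so the two cannot be told apart in this assay on this evidence. The next compound, compound 3 (`COc1c(N2CCN(C)CC2)c(F)cc2c(=O)c(C(=O)N/N=C\c3cccc(O)c3)cn(C3CC3)c12`), keeps the core of compound 2 and changes one group: 3-hydroxyphenyl in place of 2,5-dimethoxyphenyl on a carbon with a double bond to nitrogen. In words, 3-hydroxyphenyl stands in place of 2,5-dimethoxyphenyl on a carbon with a double bond to nitrogen.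

Among the measured compounds shown here, one measured step bears on this, as it changes the group at the same place: a 1.6-fold lower number from compound 1 to compound 2 (0.21 log units; within the scatter). That step stays within the scatter. For the measured compounds named here, it is thin evidence, since no measured compound carries 3-hydroxyphenyl, so the range must stay wide. No step beyond the scatter is expected in this assay, and the estimated change is a 1.3-fold higher number from compound 2 to compound 3 (0.10 log units; within the scatter) as a best guess. Compound 3 is expected at 3.8 ug/mL, with an estimated range from 1.5 ug/mL to 9 ug/mL as the likely span.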

Compound 3, half-maximal inhibitory concentration: 3.4 ug/mL
For compound 3 the middle estimate is 1.1-fold (0.05 log units) above the measured one; the range from low to high includes it.
By their numbers in this assay, from the lowest: compounds 2, 3 and 1 (each within the scatter of the next).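

In this assay, putting 3-hydroxyphenyl on a carbon with a double bond to nitrogen gives a 1.1-fold higher number from compound 2 to compound 3 (0.05 log units; within the scatter) when it replaces 2,5-dimethoxyphenyl and a 1.4-fold lower number from compound 1 to compound 3 (0.16 log units; within the scatter) when it replaces 2,6-dichlorophenyl, so three different phenyl groups at this place now cannot be told apart. The new point is that this holds for a real change in the counted features of the group: 3-hydroxyphenyl has 7 heavy atoms, 1 hydrogen-bond donor and 1 hydrogen-bond acceptor, while 2,5-dimethoxyphenyl has 10 heavy atoms, 0 donors and 2 acceptors, and the step still stays within the scatter. No measurement offered here explains why these groups read alike.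

As far as these compounds go, all three groups are phenyl rings, so it remains open whether a group of another kind at this place, such as an amine, a carboxylic acid or a longer carbon chain, would give a step beyond the scatter. From the compounds shown here alone, it also remains open whether the same closeness of these three compounds would hold in any test other than this one on PC-3 cells.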